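A few compounds are considered here, and "the series" means these few. Any claim that something is new, unique, unknown or untested is made for them only; others in the source may bear on it.

In a functional assay on SU-DHL-6 cells (Homo sapiens) for antiproliferative activity, read by MTT assay (a lower number here means a stronger inhibitor, a higher number a weaker inhibitor), compound 1 `COc1ncc(-c2ccc3ncnc(N[C@H]4CCCN(C(=O)C5CCOCC5)C4)c3c2)cc1C#N` gives 150 nM and compound 2 `COc1ncc(-c2ccc3ncnc(N[C@H]4CCCN(C(=O)C(C)N)C4)c3c2)cc1C#N` gives 440 nM, so compound 2 holds the higher, weaker number of the two. Compound 3 `COc1ncc(-c2ccc3ncnc(N[C@H]4CCCN(C(=O)C5CCNCC5)C4)c3c2)cc1C#N` has not yet been measured. It keeps everything in compound 2 except one group: piperidin-4-yl in place of 1-aminoethyl on a carbonyl carbon. In short, piperidin-4-yl stands in place of 1-aminoethyl on a carbonyl carbon.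

For the measured compounds named here, only one measured step bears on this change. Putting 1-aminoethyl in place of oxan-4-yl at that same carbonyl carbon gave a 2.9-fold higher number from compound 1 to compound 2 (0.47 log units; beyond the scatter), a modest change. Going by the values given here, the new group again brings a six-membered non-aromatic ring with one hetero atom, but that atom is nitrogen, and no measurement yet shows what this difference from compound 1 does. Among the compounds with values here, with compound 1 at 150 nM as the only measured compound carrying such a ring, a modest move toward a lower number is expected in this assay. The expected size is a 2.0-fold lower number from compound 2 to compound 3 (0.30 log units; within the scatter). For compound 3 the estimated value is 220 nM, with an expected range from 80 nM to 600 nM.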

Compound 3, half-maximal inhibitory concentration: 2440 nM
For compound 3 the middle estimate is 11-fold (1.04 log units) below the measured one, and the stated range ends below it.
By their numbers in this assay, from the lowest: compound 1; then compound 2; then compound 3.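

The step of a 16-fold higher number from compound 1 to compound 3 (1.21 log units; beyond the scatter) is a large one in this assay, and it comes from exchanging oxan-4-yl for piperidin-4-yl, two six-membered non-aromatic rings that each hold one hetero atom. At this carbonyl carbon, then, having such a ring does not by itself keep the number low, and the identity of the hetero atom matters a great deal. The open-chain 1-aminoethyl group also does better than the nitrogen-containing ring, with a 5.5-fold higher number from compound 2 to compound 3 (0.74 log units; beyond the scatter) on moving to the ring, so among these three compounds neither the presence of a ring nor the presence of a nitrogen gives a simple ordering; no measurement shown explains this result.

On these data alone, it remains open whether the ring nitrogen itself drives the loss, which a cyclohexyl group, with only carbon in its ring, would help to test against oxan-4-yl and piperidin-4-yl. A piperidin-4-yl carrying a methyl or acetyl group on its nitrogen would show whether changing that atom brings the number back toward that of compound 1.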